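Side Chain Change and Expected Cytotoxicity in Compound 3

The compounds below may be only part of what the source reports. "The series", "measured", "known", "first", "only" and "open" are said of these compounds alone.

Compound 2 `O=CNC[C@H]1CN(c2ccc(-n3cc(-c4ccccn4)cn3)c(F)c2)C(=O)O1` is a close relative of compound 1 `CN(CCC#N)C[C@H]1CN(c2ccc(-n3cc(-c4ccccn4)cn3)c(F)c2)C(=O)O1`, the two sharing a core and differing only in one side chain. In an ADME assay on L02 cells (Homo sapiens) for cytotoxicity, read by MTT assay, with a stated time of 48 h (a higher number here means a weaker inhibitor, a lower number a stronger inhibitor), compound 1 reaches only the limit of the assay, > 400 ug/mL. In this assay compound 2 likewise stops at a limit, > 400 ug/mL. The step that the two limits leave unreadable from compound 1 to compound 2 therefore cannot be read, because both values sit at the limit of > 400 ug/mL in this assay, at which 2 of the 2 values shown sit. Compound 2 thus stands at the upper end of what this assay reports.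

Compound 3 `CONC(=O)[C@H]1CN(c2ccc(-n3cc(-c4ccccn4)cn3)c(F)c2)C(=O)O1` differs from compound 2 by methoxycarbamoyl in place of (formylamino)methyl on a saturated ring carbon. Among the measured compounds shown here, the one measured step, the exchange of (2-cyanoethyl)(methyl)amino for formylamino on the side chain, gives no size, so no direction can be drawn from it; the only evidence is that both relatives sit at the limit. Compound 3 is therefore expected to show a step of a number no higher from compound 2 to compound 3 (the limit leaves the size open) that is none beyond the scatter, with the value most likely again reported as a limit. The estimate for compound 3 in this assay is 400 ug/mL, within a range from 200 ug/mL to 800 ug/mL.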

Compound 3, half-maximal inhibitory concentration: > 400 ug/mL
Compound 3: only a limit was reported; the forecaster's own chance of this, stated with the estimate: 85%; the middle value sits exactly at the limit.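

In this assay compound 3 also reaches only a limit of the assay, so the steps among compound 1, compound 2 and compound 3 cannot be read, because all three share one reading: the limit of > 400 ug/mL in this assay, at which 3 of the 3 values shown sit. The compounds shown leave open whether any of these side chain changes alters cytotoxicity at all.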